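The compounds below may be only part of what the source reports. "The series", "measured", "known", "first", "only" and "open" are said of these compounds alone.

Among the compounds with values here, compound 1, with structure `CCOc1c(-c2occ(C)c2CO)ccc2c1CCCC2(C)C`, is one of three compounds measured in a functional assay on SK-BR-3 cells (Homo sapiens) for cytotoxicity, read by sulforhodamine B assay, with a stated time of 3 days (a higher number here means that more compound is needed for the effect, a lower number that less compound is needed), and in this assay compound 1 gives 9.9 uM. Compound 2, with structure `Cc1coc(-c2ccc3c(c2O)CCCC3)c1C(=O)O`, gives 32.4 uM in this assay, and compound 3, with structure `Cc1coc(-c2ccc3c(c2O)CCC3)c1C(=O)O`, gives 30.2 uM. Of the three numbers, that of compound 1 is the lowest, and its distance from each of the other two lies beyond the usual scatter of this assay. The two others differ from compound 1 at several places at once, so their numbers say little about any single change.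

Compound 4, with structure `COc1c(-c2occ(C)c2CO)ccc2c1CCCC2(C)C`, differs from compound 1 in one place only: hydrogen in place of methyl on a saturated chain carbon bound to an oxygen on an aromatic ring. Within the data shown here, the change is small, and no pair of measured compounds shows what such a change does here. On that basis the step is expected to be small, in no fixed direction, and the step of a 1.1-fold higher number from compound 1 to compound 4 (0.05 log units; within the scatter) is estimated to stay within the scatter. Compound 4 is therefore expected to give about 11 uM in this assay, in a range from 4 uM to 30 uM.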

Compound 4, concentration for half-maximal effect: 23.7 uM
Compound 4: middle estimate off by 2.2-fold (0.33 log units), on the low side; low and high end bracket the measured number.
By their numbers in this assay, from the lowest: compound 1; then compounds 4, 3 and 2 (each within the scatter of the next).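

In this assay, within the data shown here, this is the first comparison that isolates a single change, and it shows that the group on this oxygen is not indifferent: the step of a 2.4-fold higher number from compound 1 to compound 4 (0.38 log units; beyond the scatter) lies beyond the scatter with the rest of the structure held constant. Ethoxy going to methoxy removes one carbon and no hydrogen-bond donor or acceptor, and that alone moves the number towards more compound being needed, so ethoxy stands with the lower number of this pair. Nothing shown here accounts for this difference.

The compounds shown leave open whether a longer chain on this oxygen, such as propoxy or butoxy, would lower the number further or raise it again, since a single step sets no trend. They also leave open what an amine at the end of such a chain would do.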